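The source may report more compounds than this note shows. Statements on the series, on what has been measured and on what is new or still open speak of the compounds shown alone.

Measured so far in an assay on HEK293 cells for agonist activity at Toll-like receptor 2 (Homo sapiens); on this read-out lower numbers stand for an effect already at smaller amounts and higher numbers for an effect only at larger amounts of compound:
compound 1 `CCCCCCCCCCCC(=O)OC[C@H](CSC[C@@H](N)C(=O)NC(C)c1ccccc1)OC(=O)CCCCCCCCCCC`, where compound 1 gives 9900 nM
compound 2 `CCCCCCCCCCCC(=O)OC[C@H](CSC[C@@H](N)C(=O)NC(C)CCC(C)C)OC(=O)CCCCCCCCCCC`, where compound 2 gives 190 nM
compound 3 `CCCCCCCCCCCC(=O)OC[C@H](CSC[C@@H](N)C(=O)NCCOCCOCCOCCC(=O)O)OC(=O)CCCCCCCCCCC`, where compound 3 gives 900 nM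

Compound 3 stands second highest of these three numbers: compound 2 lies lower, compound 1 higher. Compound 4 `CCCCCCCCCCCC(=O)OC[C@H](CSC[C@@H](N)C(=O)NCCCN)OC(=O)CCCCCCCCCCC` differs from compound 3 by aminomethyl in place of 2-(2-(2-carboxyethoxy)ethoxy)ethoxy on a saturated chain carbon, two bonds along the chain from an amide-type nitrogen. For the measured compounds named here, the only measured step, a 52-fold lower number from compound 1 to compound 2 (1.72 log units; beyond the scatter), changes the group on the amide-type nitrogen itself, a different place, so it shows merely that this region tolerates large shifts in this assay. Going by the values given here, no measured step touches the chain two bonds from the nitrogen. A modest step is therefore expected for compound 4, a 1.8-fold lower number from compound 3 to compound 4 (0.26 log units; within the scatter), toward a somewhat lower number. The estimate for compound 4 is 500 nM, in a range from 100 nM to 2500 nM.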

Compound 4, half-maximal effective concentration: 1960 nM
Compound 4: middle estimate off by 3.9-fold (0.59 log units), on the low side; the measured number falls inside the stated range.
By their numbers in this assay, from the lowest: compound 2; then compound 3; then compound 4; then compound 1.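

Replacing 2-(2-(2-carboxyethoxy)ethoxy)ethoxy with aminomethyl, two bonds along the chain from an amide-type nitrogen, gives (a 2.2-fold higher number from compound 3 to compound 4 (0.34 log units; beyond the scatter)), so this position responds to the change, but only modestly. With 3-aminopropyl on the amide-type nitrogen, the comparisons run in opposite directions: (a 10-fold higher number from compound 2 to compound 4 (1.01 log units; beyond the scatter)) and (a 5.1-fold lower number from compound 1 to compound 4 (0.70 log units; beyond the scatter)). No supporting measurement explains these shifts.

The change from compound 3 to compound 4 alters both the length of the chain and the group at its end, and these two changes cannot be separated here. A longer chain ending in an amine, or a short chain ending in a carboxylic acid, would help to separate them.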